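A few compounds are considered here, and "the series" means these few. Any claim that something is new, unique, unknown or untested is made for them only; others in the source may bear on it.

Three analogues on the shared core have numbers in an assay on mitochondria from L6 cells (Rattus norvegicus) for activation, with a stated time of 90 min; a higher number here means that more compound is needed for the effect, a lower number that less compound is needed. Compound 1 `Oc1nc2nonc2nc1Nc1ccccc1` gives 66700 nM. Compound 2 `CC(C)(C)c1ccc(Nc2nc3nonc3nc2O)cc1` gives 3900 nM. Compound 3 `Oc1nc2nonc2nc1Nc1ccc(F)cc1` gives 38600 nM, the second highest of the three, nearest compound 1 and furthest from compound 2. Compound 4 `Oc1nc2nonc2nc1Nc1ccc(Cl)cc1` is not yet measured; it differs from compound 3 by chloro in place of fluoro on an aromatic carbon. The substitutions already seen on that aromatic carbon bear on it: a 1.7-fold lower number from compound 1 to compound 3 (0.24 log units; within the scatter), whereas a 17-fold lower number from compound 1 to compound 2 (1.23 log units; beyond the scatter) and a 9.9-fold higher number from compound 2 to compound 3 (1.00 log units; beyond the scatter). Fluoro thus gave no step beyond the scatter and tert-butyl a large lowering; chloro is expected to fall between them, so a modest lowering in this assay is expected, a 2.6-fold lower number from compound 3 to compound 4 (0.41 log units; beyond the scatter). Compound 4 is estimated at 15000 nM, with a range of 5000 nM to 40000 nM.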

Compound 4, half-maximal effective concentration: 11700 nM
The estimate for compound 4 lay 1.3-fold (0.11 log units) above the measured number; the range from low to high includes it.
By their numbers in this assay, from the lowest: compound 2; then compound 4; then compounds 3 and 1 (each within the scatter of the next).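

In this assay chloro gives a step beyond the scatter on this aromatic carbon, with a 3.3-fold lower number from compound 3 to compound 4 (0.52 log units; beyond the scatter) and a 5.7-fold lower number from compound 1 to compound 4 (0.76 log units; beyond the scatter) in the same direction, whereas fluoro stayed within the scatter of hydrogen. Chloro does not match tert-butyl, with a 3.0-fold higher number from compound 2 to compound 4 (0.48 log units; beyond the scatter) as the remaining gap, so the listed order is compound 2, compound 4, then compounds 3 and 1 together. No measurement at hand explains this order. Open, going by these compounds, is where bromo, methoxy, an amine or a carboxylic acid on this carbon would fall, and whether any would pass tert-butyl.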